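Aryl variation on the shared core: compound 4

This account rests on a few compounds, and the source may have more. Where it says the series, first, only, none or still open, it means among the compounds named here.

Measured so far:
compound 1 `CCCS(=O)(=O)Nc1ccc(F)c(C(=O)c2n[nH]c3ncc(-c4ccccc4F)cc23)c1F`: 2%
compound 2 `CCCS(=O)(=O)Nc1ccc(F)c(C(=O)c2n[nH]c3ncc(-c4ccccc4N)cc23)c1F`: 23%
compound 3 `CCCS(=O)(=O)Nc1ccc(F)c(C(=O)c2n[nH]c3ncc(-c4cc(Cl)cc(Cl)c4)cc23)c1F`: 73%

In an assay for binding affinity to dual specificity mitogen-activated protein kinase kinase 4 (Homo sapiens), read by KINOMEscan, tested at 100 nM (a higher number here means a weaker effect of the compound at the concentration tested, a lower number a stronger effect), compound 1 gives the lowest of the three numbers, with compound 2 nearest and compound 3 furthest away. Both steps away from compound 1 raise the number: a number 21 percentage points higher from compound 1 to compound 2 (beyond the scatter) and a number 71 percentage points higher from compound 1 to compound 3 (beyond the scatter). Between the two other compounds the step of a number 50 percentage points higher from compound 2 to compound 3 (beyond the scatter) is also large.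

Compound 4 `CCCS(=O)(=O)Nc1ccc(F)c(C(=O)c2n[nH]c3ncc(-c4ccc(C(C)C)cc4)cc23)c1F` has not been measured. It differs from compound 1 in one place: 4-isopropylphenyl in place of 2-fluorophenyl on an aromatic carbon. For the measured compounds named here, the steps that bear on this are those from compound 1 to compound 2 and from compound 1 to compound 3, where a change on the same aryl group raised the number modestly in one case and by a large amount in the other. A rise beyond the scatter in this assay is therefore expected for compound 4 as well, and the expected step is a number 53 percentage points higher from compound 1 to compound 4 (beyond the scatter). Compound 4 is estimated at 55%, with a range from 15% to 95%.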

Compound 4, a percentage reported as activity, at one concentration (the size of the read-out at that concentration, not a potency): 17%
Estimate against measurement, compound 4: 38 percentage points above; low and high end bracket the measured number.
By their numbers in this assay, from the lowest: compound 1; then compounds 4 and 2 (each within the scatter of the next); then compound 3.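

In this assay, a phenyl group bearing a branched alkyl substituent is tolerated far better at this position than compound 3 suggested: the change to 4-isopropylphenyl gives only a number 15 percentage points higher from compound 1 to compound 4 (beyond the scatter), against a number 56 percentage points lower from compound 3 to compound 4 (beyond the scatter). Compound 2 and compound 4 cannot be told apart, with a number 6 percentage points lower from compound 2 to compound 4 (within the scatter), so the 2-aminophenyl and 4-isopropylphenyl groups sit at a similar level, and the 3,5-dichlorophenyl group of compound 3 alone stands well apart from the other three. No independent data on hand account for these differences.

Since compound 1 and compound 4 differ in both substituent and ring position, a 4-fluorophenyl or 2-isopropylphenyl group would be needed to separate the two. Also open, on these data alone, is how this position responds to a 4-carboxylic acid, a 4-aminomethyl group or a longer alkyl chain.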